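This account rests on a few compounds, and the source may have more. Where it says the series, first, only, none or still open, it means among the compounds named here.

Compounds measured in a functional assay on HepG2 cells for inhibition of squalene monooxygenase (Homo sapiens); on this read-out lower numbers stand for stronger inhibition and higher numbers for weaker inhibition:
compound 1, `CCN(C/C=C/C#CC(C)(C)C)Cc1cccc(OCCN(C)S(=O)(=O)c2ccsc2)c1`: 250 nM
compound 2, `CCN(C/C=C/C#CC(C)(C)C)Cc1cccc(OCCN(C)S(=O)(=O)c2ccc(Br)s2)c1`: 390 nM
compound 3, `CCN(C/C=C/C#CC(C)(C)C)Cc1cccc(OCCN(C)S(=O)(=O)c2cc(-c3ccsc3)cs2)c1`: 90 nM

Compound 3 stands at the lowest number of the three: a 2.8-fold lower number from compound 1 to compound 3 (0.44 log units; beyond the scatter) and a 4.3-fold lower number from compound 2 to compound 3 (0.64 log units; beyond the scatter) are both beyond the scatter, whereas a 1.6-fold higher number from compound 1 to compound 2 (0.19 log units; within the scatter) stays within it. Compound 4, `CCN(C/C=C/C#CC(C)(C)C)Cc1cccc(OCCN(C)S(=O)(=O)c2ccc(-c3ccsc3)s2)c1`, is the next compound; the change is 5-(thiophen-3-yl)thiophen-2-yl in place of 4-(thiophen-3-yl)thiophen-2-yl on a sulfonyl sulfur. Among the compounds with values here, no measured step moves a group from one place to another on the ring attached to the sulfonyl sulfur. The steps that bear at all are those putting the thiophen-3-yl-bearing ring in place of thiophen-3-yl or 5-bromothiophen-2-yl, which lowered the number modestly. Compound 4 keeps that ring, so no step beyond the scatter is expected, a 1.2-fold higher number from compound 3 to compound 4 (0.09 log units; within the scatter). Compound 4 is estimated at 110 nM, range 45 nM to 280 nM.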

Compound 4, half-maximal inhibitory concentration: 210 nM
The estimate for compound 4 lay 1.9-fold (0.28 log units) below the measured number; the measured number falls inside the stated range.
By their numbers in this assay, from the lowest: compound 3; then compounds 4, 1 and 2 (each within the scatter of the next).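

In this assay, the same atoms joined differently are not equivalent: 5-(thiophen-3-yl)thiophen-2-yl in place of 4-(thiophen-3-yl)thiophen-2-yl on a sulfonyl sulfur gives a 2.3-fold higher number from compound 3 to compound 4 (0.37 log units; beyond the scatter). The second thiophene alone therefore does not secure the lower number, as a 1.9-fold lower number from compound 2 to compound 4 (0.27 log units; within the scatter) and a 1.2-fold lower number from compound 1 to compound 4 (0.08 log units; within the scatter) both remain within the scatter. Nothing available explains the difference between the two arrangements.

Open, going by these compounds, is whether phenyl or pyridine in place of the outer thiophen-3-yl keeps the number of compound 3, and whether an amine or a carboxylic acid is tolerated there.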